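A Ring Enters the Side Chain of Compound 2

A few compounds are considered here, and "the series" means these few. Any claim that something is new, unique, unknown or untested is made for them only; others in the source may bear on it.

In a functional assay on MDA-MB-231 cells (Homo sapiens) for cytotoxicity, read by MTT assay, with a stated time of 72 h (a higher number here means a weaker inhibitor, a lower number a stronger inhibitor), compound 1 `CN1CCCCC1CCO/N=C1C(=C2/C(=O)Nc3ccc(F)cc32)/Nc2ccccc2/1` gives 530 nM as its number and compound 2 `CN(C)CCCO/N=C1C(=C2/C(=O)Nc3ccccc32)/Nc2ccccc2/1` gives 440 nM as its number. Within the data shown here, that gap lies within the scatter, so compound 2 stands level with the only other measured compound. Compound 3 `CN1CCCC1CCO/N=C1C(=C2/C(=O)Nc3ccccc32)/Nc2ccccc2/1` keeps the core of compound 2 and alters the side chain 1-methylpyrrolidin-2-yl in place of (dimethylamino)methyl on a saturated chain carbon, two bonds along the chain from an oxygen on an unsaturated carbon by placing 1-methylpyrrolidin-2-yl in place of (dimethylamino)methyl on a saturated chain carbon, two bonds along the chain from an oxygen on an unsaturated carbon. Among the measured compounds shown here, no measured pair isolates this kind of change, so the guide is thin. Compound 1 at 530 nM and compound 2 at 440 nM are the only reference points and they sit close together, so no step beyond the scatter is expected in this assay in either direction. The expected change a 1.0-fold higher number from compound 2 to compound 3 (0.01 log units; within the scatter) is therefore small. Compound 3 is estimated at 450 nM with a likely range of 210 nM to 950 nM when tested.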

Compound 3, half-maximal inhibitory concentration: 250 nM
Estimate against measurement, compound 3: 1.8-fold (0.26 log units) above; the range from low to high includes it.
By their numbers in this assay, from the lowest: compounds 3, 2 and 1 (each within the scatter of the next, the first and the last beyond it).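

Swapping (dimethylamino)methyl for 1-methylpyrrolidin-2-yl gives a 1.8-fold lower number from compound 2 to compound 3 (0.25 log units; within the scatter) in this assay, the first step measured at this place on the side chain. The step shows that this spot on the chain can take a five-membered non-aromatic ring in place of an open amine and still leave the number within the scatter of compound 2. Among these compounds, as only one such pair is available, this holds for this single change and not for ring groups in general. No supporting measurement is available to explain the size of this step. The compounds shown leave open how a morpholin-4-yl group or a carboxylic acid would behave at this place on the chain. They also leave open whether a longer chain carrying the same 1-methylpyrrolidin-2-yl group would give a number beyond the scatter.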